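Pyridin-2-yl Amide in Place of the Cinnamoyl Group

The source may hold more compounds than are shown below. What is called first, only, known or untested is meant among the compounds shown, and "the series" means these compounds.

Compound 1, `Nc1ccc(C(=O)Nc2nnc(-c3ccc4c(c3)OCCO4)s2)cc1`, gives > 100 ug/mL in a functional assay on HepG2 cells (Homo sapiens) for antiproliferative activity, read by MTT assay, with a stated time of 48 h; a lower number here means that less compound is needed, a higher number that more compound is needed for the effect.
Compound 2, `O=C(/C=C/c1ccccc1)Nc1nnc(-c2ccc3c(c2)OCCO3)s1`, gives 10.3 ug/mL in this assay.

Compound 1 sits at a limit of this assay, (the limit of > 100 ug/mL in this assay, at which 1 of the 2 values shown sits), so no number is known for it. Among the measured compounds shown here, compound 2 gives the only number in this set, 10.3 ug/mL, and so stands as the sole fixed point. For the measured compounds named here, the one measured step, an at least 9.7-fold lower number from compound 1 to compound 2 (0.98 log units; beyond the scatter), shows that putting 2-phenylethenyl on the carbonyl carbon in place of 4-aminophenyl brings the compound from the limit down to a measurable number.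

Compound 3, `O=C(Nc1nnc(-c2ccc3c(c2)OCCO3)s1)c1ccccn1`, differs from compound 2 by pyridin-2-yl in place of 2-phenylethenyl on a carbonyl carbon. Going by the values given here, this step undoes the one measured step in part: the 2-phenylethenyl that had produced the gain now leaves, and a six-membered aromatic ring again sits directly on the carbonyl carbon. The measured step therefore points toward a higher number for compound 3 in this assay, though pyridin-2-yl is not 4-aminophenyl, so the return need not reach the limit. Compound 3 is expected to give 40 ug/mL, between 12 ug/mL and 100 ug/mL, a step of a 3.9-fold higher number from compound 2 to compound 3 (0.59 log units; beyond the scatter).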

Compound 3, half-maximal effective concentration: > 100 ug/mL
Compound 3: a limit, no number (the forecaster's own chance of this, stated with the estimate: 35%); at least 2.5-fold (0.39 log units) between middle value and limit.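

In this assay compound 3 gives > 100 ug/mL, which is a limit and not a number. Setting pyridin-2-yl on the carbonyl carbon in place of 2-phenylethenyl gives an at least 9.7-fold higher number from compound 2 to compound 3 (0.98 log units; beyond the scatter), so the change from compound 2 is now measured against a second group, and both aromatic rings set directly on that carbon, 4-aminophenyl in compound 1 and pyridin-2-yl in compound 3, go with a limit, while compound 2 alone of the three has a number. Compound 1 and compound 3 cannot be ranked against each other, and the step between them cannot be read: the limit of > 100 ug/mL in this assay, at which 2 of the 3 values shown sit.

The compounds shown leave open whether the number of compound 2 depends on the double bond of 2-phenylethenyl, which a saturated 2-phenylethyl chain on the same carbonyl carbon would test, or only on the ring standing further from that carbon. They also leave open whether a 2-(pyridin-2-yl)ethenyl group, which keeps the double bond and brings in the ring nitrogen, would go with compound 2 or with the compounds at the limit.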